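Extending the aryl ether of compound 3 to a 3-bromobenzyl group

The source may hold more compounds than are shown below. What is called first, only, known or untested is meant among the compounds shown, and "the series" means these compounds.

Compound 1 `CCOc1ccc2cc(C(=O)NCCO)c(=O)oc2c1`: > 100000 nM
Compound 2 `CCN(CC)c1ccc2cc(C(=O)NC(C)C)c(=O)oc2c1`: 73000 nM
Compound 3 `CCOc1ccc2cc(C(=O)NN)c(=O)oc2c1`: 38300 nM

Of the compounds shown here, three sharing one coumarin-type core have been tested in a functional assay on HeLa cells (Homo sapiens) for cytotoxicity, read by MTT assay, with a stated time of 72 h; a lower number here means a stronger inhibitor, a higher number a weaker inhibitor. Compound 1 reaches only the limit of the assay, > 100000 nM, which is a boundary rather than a number (the limit of > 100000 nM in this assay, at which 1 of the 3 values shown sits). Compound 2 gives 73000 nM, and compound 3 gives 38300 nM, the lowest of the two numbers; the gap between compound 2 and compound 3 stays within the usual scatter, so neither can be called the stronger. Within the data shown here, the one step measured at a single place, an at least 2.6-fold lower number from compound 1 to compound 3 (0.41 log units; beyond the scatter), concerns the amide nitrogen.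

Compound 4 `NNC(=O)c1cc2ccc(OCc3cccc(Br)c3)cc2oc1=O` is not yet measured. It differs from compound 3 at the ether oxygen on the ring: 3-bromophenyl in place of methyl on a saturated chain carbon bound to an oxygen on an aromatic ring. Among the measured compounds shown here, no measured step touches this position; the change from compound 1 to compound 3 lies elsewhere, and compound 2 differs from compound 3 in two places at once, so it offers no single-place guide. With nothing to anchor the direction, the step of a 1.9-fold lower number from compound 3 to compound 4 (0.28 log units; within the scatter) is expected to be small, and compound 4 is estimated at 20000 nM, within a range of 4000 nM to 90000 nM.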

Compound 4, half-maximal inhibitory concentration: > 100000 nM
Compound 4 ended at the assay's limit; the forecaster's own chance of this, stated with the estimate: 10%; middle value at least 5.0-fold (0.69 log units) from the limit.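

Among these compounds, this is the first measured step at this place on the shared core, and it goes towards a weaker compound: in this assay there is an at least 2.6-fold higher number from compound 3 to compound 4 (0.41 log units; beyond the scatter). The amino group on the amide-type nitrogen, which came with an at least 2.6-fold lower number from compound 1 to compound 3 (0.41 log units; beyond the scatter), is present in compound 4 as well, so that group alone does not keep the number low once ethyl gives way to 3-bromobenzyl. Compound 4 stands at a limit and not at a number, so the step has a known minimum but no known size, and the limit now recurs in the series: the limit of > 100000 nM in this assay, at which 2 of the 4 values shown sit.

On these data alone, what remains open is which part of the change matters, since 3-bromobenzyl brings in both an aromatic ring and a bromine, and only a plain benzyl group would separate the two. Equally open, as far as these compounds go, is how the number responds to something intermediate at this place, such as a propyl or butyl chain, or a chain ending in an amine.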